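The compounds below may be only part of what the source reports. "The series", "measured", "known", "first", "only" and "open" are said of these compounds alone.

Working notes on the series in a functional assay for inhibition, tested at 60 ug/mL; on this read-out lower numbers stand for a weaker effect and higher numbers for a stronger effect at the one concentration tested.

Three compounds share one core and differ in the group attached on an aromatic carbon. Compound 1 `Cc1cc(O)c(C(C)C)cc1-c1cc(-c2ccccc2Cl)c(C#N)c(=O)[nH]1` gives 26% in this assay. Compound 2 `Cc1cc(O)c(C(C)C)cc1-c1cc(-c2cccs2)c(C#N)c(=O)[nH]1` gives 54.3%, and compound 3 `Cc1cc(O)c(C(C)C)cc1-c1cc(-c2ccco2)c(C#N)c(=O)[nH]1` gives 55.2%. Compound 2 thus stands second highest of the three numbers: its nearest neighbour is compound 3, and a number 0.9 percentage points higher from compound 2 to compound 3 (within the scatter), which is within the scatter; its furthest is compound 1, and a number 28.3 percentage points higher from compound 1 to compound 2 (beyond the scatter), which is beyond the scatter.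

Compound 4 `COc1cccc(-c2cc(-c3cc(C(C)C)c(O)cc3C)[nH]c(=O)c2C#N)c1` is not yet measured. It differs from compound 2 in one place: 3-methoxyphenyl in place of thiophen-2-yl on an aromatic carbon.

The step that bears most on this is the one where a six-membered carbon-only ring gave way to thiophen-2-yl, a number 28.3 percentage points higher from compound 1 to compound 2 (beyond the scatter). The step that exchanged thiophen-2-yl for furan-2-yl, a number 0.9 percentage points higher from compound 2 to compound 3 (within the scatter), stayed within the scatter. Among the measured compounds shown here, no measured pair carries 3-methoxyphenyl, so the size of a return to a six-membered carbon-only ring is uncertain; a decrease is expected, of moderate size, namely a number 16.3 percentage points lower from compound 2 to compound 4 (beyond the scatter). For compound 4 the estimate is 38%, with a range from 18% to 58%.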

Compound 4, a percentage reported as inhibition, at one concentration (the size of the read-out at that concentration, not a potency): 38%
Estimate against measurement, compound 4: no gap at the digits printed; measured number inside the range.
By their numbers in this assay, from the lowest: compound 1; then compound 4; then compounds 2 and 3 (each within the scatter of the next).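

A six-membered carbon-only ring at this position does not by itself fix the low end of this assay since 3-methoxyphenyl in place of 2-chlorophenyl gives a number 12 percentage points higher from compound 1 to compound 4 (beyond the scatter) and so separates the two such rings. It still does not match either five-membered aromatic ring, with a number 16.3 percentage points lower from compound 2 to compound 4 (beyond the scatter) and a number 17.2 percentage points lower from compound 3 to compound 4 (beyond the scatter) as the two steps, and among these four compounds both five-membered rings stand above both six-membered rings, with no compound against that order. No measurement at hand explains these gaps.

The compounds shown leave open whether the gap between the two six-membered rings follows the chlorine or the methoxy group and where each sits, which unsubstituted phenyl, 3-chlorophenyl or 2-methoxyphenyl would help to separate. Also open, on these data alone, is how a ring carrying an amine or a carboxylic acid would read here.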